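From dihydroxyphenyl to plain phenyl at the assay limit

The compounds below may be only part of what the source reports. "The series", "measured", "known", "first", "only" and "open" are said of these compounds alone.

Compound 1 `O=C(O)/C=C/c1cn(-c2ccc(O)cc2)nc1-c1cccc(O)c1` gives > 100000 nM as a limit
Compound 2 `O=C(O)/C=C/c1cn(-c2ccc(O)cc2)nc1-c1ccc(O)cc1` gives > 100000 nM as a limit
Compound 3 `O=C(O)/C=C/c1cn(-c2ccc(O)cc2)nc1-c1cc(O)ccc1O` gives > 100000 nM as a limit

In a functional assay (Mus musculus) for inhibition, with a stated time of 5 days (on this read-out lower numbers stand for stronger inhibition and higher numbers for weaker inhibition), compound 3 reads > 100000 nM as a limit and not as a number. On the numbers, nothing separates the three compounds (the limit of > 100000 nM in this assay, at which 3 of the 3 values shown sit) so far. Compound 4 `O=C(O)/C=C/c1cn(-c2ccc(O)cc2)nc1-c1ccccc1` has phenyl in place of 2,5-dihydroxyphenyl on an aromatic carbon and is otherwise the same as compound 3.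

Going by the values given here, three measured steps concern this same group: a step that the two limits leave unreadable from compound 1 to compound 2 and a step that the two limits leave unreadable from compound 1 to compound 3 and also a step that the two limits leave unreadable from compound 2 to compound 3 offer no size to carry over. They give no direction either. The expected step is a number no higher from compound 3 to compound 4 (the limit leaves the size open) and none beyond the scatter is foreseen in this assay on this evidence. A reading at the same limit would be no surprise. For compound 4 the estimated value is 100000 nM with an expected range from 30000 nM to 300000 nM as a best guess.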

Compound 4, half-maximal inhibitory concentration: > 100000 nM
Compound 4 was reported as a limit; the forecaster's own chance of this, stated with the estimate: 75%; the middle value sits exactly at the limit.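

Compound 4 is reported only as a limit, just like compound 1, compound 2 and compound 3, so no step among these four compounds can be read: the limit of > 100000 nM in this assay, at which 4 of the 4 values shown sit.

What the compounds shown leave open is whether phenyl, 3-hydroxyphenyl, 4-hydroxyphenyl and 2,5-dihydroxyphenyl differ at all in inhibition.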